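This account rests on a few compounds, and the source may have more. Where it says the series, first, only, none or still open, it means among the compounds named here.

Measured in a functional assay on MDA-MB-231 cells (Homo sapiens) for antiproliferative activity, read by MTT assay, with a stated time of 72 h; a higher number here means a weaker inhibitor, a lower number a stronger inhibitor:
- compound 1 `CCn1ccnc1-c1cc(OC)c(OC)c(OC)c1`: > 100000 nM (a limit, not a number)
- compound 2 `CCCCCn1ccnc1-c1cc(OC)c(OC)c(OC)c1`: 34200 nM
- compound 3 `COc1cccc(-n2ccnc2-c2cc(OC)c(OC)c(OC)c2)c1`: 18300 nM

Among the compounds with values here, only two of the three readings are true numbers, and the gap between them is a 1.9-fold lower number from compound 2 to compound 3 (0.27 log units; within the scatter). Within the data shown here, compound 3 therefore sits level with its only numeric neighbour in this assay, and the low end of the set is not resolved.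

The unmeasured compound 4 `COc1cc(-c2nccn2-c2ccc(F)cc2)cc(OC)c1OC` has 4-fluorophenyl in place of 3-methoxyphenyl on an aromatic nitrogen.

Two measured steps change the group at this nitrogen or its chain, and both lead away from the limit: an at least 2.9-fold lower number from compound 1 to compound 2 (0.46 log units; beyond the scatter) and an at least 5.4-fold lower number from compound 1 to compound 3 (0.73 log units; beyond the scatter). Going by these compounds, both start from the limit of > 100000 nM in this assay, at which 1 of the 3 values shown sits, so their true size remains open. Neither exchanges one aromatic group for another. Among the measured compounds shown here, compound 3 is the only measured compound with an aromatic group at that nitrogen. The nearest guide is the swap of pentyl for 3-methoxyphenyl, which gave a 1.9-fold lower number from compound 2 to compound 3 (0.27 log units; within the scatter). On these data alone, the aromatic group is retained in compound 4, so no change beyond the scatter is expected, and the direction remains open. The expected change is a 1.1-fold higher number from compound 3 to compound 4 (0.04 log units; within the scatter).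

Compound 4 is estimated at 20000 nM, with an expected range of 6000 nM to 70000 nM.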

Compound 4, half-maximal inhibitory concentration: 38400 nM
The estimate for compound 4 lay 1.9-fold (0.28 log units) below the measured number; measured number inside the range.
By their numbers in this assay, from the lowest: compounds 3, 2 and 4 (each within the scatter of the next, the first and the last beyond it). At a limit, above all of these: compound 1.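

In this assay, within the data shown here, the only exchange of one aromatic group for another at this nitrogen gives a 2.1-fold higher number from compound 3 to compound 4 (0.32 log units; beyond the scatter) and so shows, modestly, that the position responds to which substituted phenyl it carries, which the changes from ethyl and pentyl could not show. An aromatic group at the nitrogen does not by itself set a compound apart from the alkyl series, since the step of a 1.1-fold higher number from compound 2 to compound 4 (0.05 log units; within the scatter) leaves 4-fluorophenyl level with pentyl. Compound 1 stands at a limit, not a number, so an at least 2.6-fold lower number from compound 1 to compound 4 (0.41 log units; beyond the scatter) gives only a bound on that change: the limit of > 100000 nM in this assay, at which 1 of the 4 values shown sits.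

The step from 3-methoxyphenyl to 4-fluorophenyl changes both the substituent and its place on the phenyl ring, and the compounds shown do not separate these two changes, which a 3-fluorophenyl or 4-methoxyphenyl group at the same nitrogen would begin to do. Also open, going by these compounds, is how an unsubstituted phenyl, or a phenyl bearing an amine or a carboxylic acid, would read at this nitrogen.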